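A few compounds are considered here, and "the series" means these few. Any claim that something is new, unique, unknown or untested is made for them only; others in the source may bear on it.

Among the compounds with values here, in a functional assay on HCT-116 cells (Homo sapiens) for antiproliferative activity, read by sulforhodamine B assay, with a stated time of 72 h (a lower number here means a stronger inhibitor, a higher number a weaker inhibitor), three analogues built on one shared core have numbers so far: compound 1 (`Cn1ncc(Cl)c1-c1cc(C(=O)N[C@@H]2CN[C@H](CCn3cncn3)C[C@H]2c2ccc(Cl)c(Cl)c2)oc1Cl`) gives 560 nM, compound 2 (`CN(C)CC[C@@H]1C[C@@H](c2ccc(Cl)c(Cl)c2)[C@H](NC(=O)c2cc(-c3c(Cl)cnn3C)c(Cl)o2)CN1`) gives 1710 nM, and compound 3 (`Cn1ncc(Cl)c1-c1cc(C(=O)N[C@@H]2CN[C@H](CC(=O)NC3CC3)C[C@H]2c2ccc(Cl)c(Cl)c2)oc1Cl`) gives 740 nM. Compound 3 sits level with one neighbour and apart from the other: the data show a 1.3-fold higher number from compound 1 to compound 3 (0.12 log units; within the scatter), and a 2.3-fold lower number from compound 2 to compound 3 (0.36 log units; beyond the scatter).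

Compound 4 (`Cn1ncc(Cl)c1-c1cc(C(=O)N[C@@H]2CN[C@H](CCN3CCCC3)C[C@H]2c2ccc(Cl)c(Cl)c2)oc1Cl`) has (pyrrolidin-1-yl)methyl in place of cyclopropylcarbamoyl on a saturated chain carbon bound to a saturated ring carbon. Within the data shown here, no measured step makes this exact exchange. Among the measured compounds shown here, the closest is the one into compound 3 from compound 2, which swaps (dimethylamino)methyl for the same cyclopropylcarbamoyl at the same place. The data also show a 3.1-fold higher number from compound 1 to compound 2 (0.48 log units; beyond the scatter), so that amine-bearing chain carries the highest number of the set.

Running the exchange the other way, a modest rise is expected in this assay, an estimated 2.0-fold higher number from compound 3 to compound 4 (0.31 log units; beyond the scatter). For compound 4 the expected value is 1500 nM, with an estimated range of 750 nM to 3000 nM.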

Compound 4, half-maximal inhibitory concentration: 1940 nM
Compound 4: middle estimate off by 1.3-fold (0.11 log units), on the low side; measured number inside the range.
By their numbers in this assay, from the lowest: compounds 1 and 3 (each within the scatter of the next); then compounds 2 and 4 (each within the scatter of the next).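

In this assay the data show a 1.1-fold higher number from compound 2 to compound 4 (0.05 log units; within the scatter) for pyrrolidin-1-yl in place of dimethylamino, so the open and the ring-closed amine stand level at this place. Both stand apart from the two other chains: the data show a 2.6-fold higher number from compound 3 to compound 4 (0.42 log units; beyond the scatter) and a 3.5-fold higher number from compound 1 to compound 4 (0.54 log units; beyond the scatter) for the compound with pyrrolidin-1-yl, which extends to all four compounds the split between the amine chains and those ending in cyclopropylcarbamoyl or 1H-1,2,4-triazol-1-yl, with none going against it. Nothing given here accounts for this split.

The compounds shown leave open whether other amines, such as morpholin-4-yl or an unsubstituted primary amine, would fall with these two. They also leave open how a carboxylic acid or a longer chain ending in pyrrolidin-1-yl would read at this place.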